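This account rests on a few compounds, and the source may have more. Where it says the series, first, only, none or still open, it means among the compounds named here.

Three thiophene carboxamides of one shared core were tested in a functional assay on HeLa cells (Homo sapiens) for antiproliferative activity, with a stated time of 24 h; a higher number here means a weaker inhibitor, a lower number a stronger inhibitor. Compound 1, `NC(=O)c1c(NC(=O)c2ccccc2Cl)sc2c1CCN(C(=S)Nc1ccc(C(F)(F)F)cc1)C2`, carries a trifluoromethyl group on the phenyl ring of its thiourea and a chlorine on its benzoyl ring. In this assay compound 1 gives only a limit, > 50000 nM. Compound 2, `COc1ccc(NC(=S)N2CCc3c(sc(NC(=O)c4ccccc4Cl)c3C(N)=O)C2)cc1`, differs from compound 1 in one place: methoxy in place of trifluoromethyl on an aromatic carbon. In this assay compound 2 gives 36400 nM, so the step is an at least 1.3-fold lower number from compound 1 to compound 2 (0.13 log units; that floor lies within the scatter).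

Compound 3, `COc1ccccc1NC(=S)N1CCc2c(sc(NC(=O)c3ccccc3C(F)(F)F)c2C(N)=O)C1`, has the methoxy group on the thiourea phenyl ring instead, and a trifluoromethyl group on the benzoyl ring; how its core differs from that of compound 1 is not broken down here. In this assay compound 3 gives only a limit, > 50000 nM. Of the values shown so far, (the limit of > 50000 nM in this assay, at which 2 of the 3 values shown sit).

Compound 4, `COc1ccccc1NC(=S)N1CCc2c(sc(NC(=O)c3ccccc3OC)c2C(N)=O)C1`, has not yet been measured in this assay. It differs from compound 3 in one place: methoxy in place of trifluoromethyl on an aromatic carbon. Among the compounds with values here, this is the same kind of change as the one from compound 1 to compound 2, but not the same: there the methoxy stood para to a large group, here it stands ortho to a large group, and on a different ring. Within the data shown here, the only measured example of this kind of change, an at least 1.3-fold lower number from compound 1 to compound 2 (0.13 log units; that floor lies within the scatter), is small and begins from a limit, so for compound 4 the expected step is an at least 1.1-fold lower number from compound 3 to compound 4 (0.04 log units; that floor lies within the scatter). The estimate for compound 4 in this assay is therefore 45000 nM, with a range from 20000 nM to 100000 nM, and a good chance that only a limit is reported again.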

Compound 4, half-maximal inhibitory concentration: > 50000 nM
Compound 4: no number, only a limit; the forecaster's own chance of this, stated with the estimate: 55%; middle value at least 1.1-fold (0.04 log units) from the limit.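

Compound 3 and compound 4 both end at a limit in this assay, so the step between them, methoxy in place of trifluoromethyl, cannot be read. Most of the series now rests on that limit: the limit of > 50000 nM in this assay, at which 3 of the 4 values shown sit. The compounds shown leave open whether methoxy in place of trifluoromethyl on this ring changes the result in this assay at all.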